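Chloro for cyano on compound 1

The source may hold more compounds than are shown below. What is called first, only, known or untested is meant among the compounds shown, and "the series" means these compounds.

In a physicochemical assay for solubility, read by nephelometry, measured as kinetic solubility, at pH 6.5 (on this read-out higher numbers stand for higher solubility and lower numbers for lower solubility), compound 1 `N#Cc1ccc(C(O)(c2ccc(C(F)(F)F)cc2)c2cccnc2)c(F)c1` gives 6.3 ug/mL, the lower of the two numbers at hand. Compound 2 `NC(=O)c1cccc(C(O)(c2ccc(Cl)cc2)c2cccnc2)c1` gives 50 ug/mL, a gap that lies beyond the usual scatter of the measurement. The next compound to be read is compound 3 `OC(c1ccc(C(F)(F)F)cc1)(c1cccnc1)c1ccc(Cl)cc1F`. It has chloro in place of cyano on an aromatic carbon, meta to a fluoro group and para to a large group: chloro in place of cyano on an aromatic carbon. Going by the values given here, no measured pair shows this change, so the only anchor for the expectation is compound 1 at 6.3 ug/mL. A small downward move, not clearly beyond the scatter, is expected in this assay, an estimated step of a 1.6-fold lower number from compound 1 to compound 3 (0.20 log units; within the scatter). Compound 3 is expected to read 4 ug/mL, with an estimated range of 1.5 ug/mL to 10 ug/mL.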

Compound 3, solubility: < 1.6 ug/mL
Compound 3 gave a limit, no number; the forecaster's own chance of this, stated with the estimate: 10%; middle value at least 2.5-fold (0.39 log units) away from the limit.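

In this assay, going by these compounds alone, the change from 4-cyano-2-fluorophenyl to 4-chloro-2-fluorophenyl is the only measured step at this position, and it gives an at least 3.9-fold lower number from compound 1 to compound 3 (0.59 log units; beyond the scatter). On the core of compound 1, then, chloro in place of cyano on an aromatic carbon, meta to a fluoro group and para to a large group, does not leave the read-out in place: the number moves down, beyond the scatter. Compound 3 stands at < 1.6 ug/mL, which is a limit of the assay and not a number, and the full size of the step stays unknown: the limit of < 1.6 ug/mL in this assay, at which 1 of the 3 values shown sits.

From the compounds shown here alone, how far compound 3 lies past that limit remains open. Also open, going by these compounds, is whether an amine or a carboxylic acid in place of the cyano would read higher or lower than compound 1.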